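A New Group on the Carbonyl of Compound 2

The source may report more compounds than this note shows. Statements on the series, on what has been measured and on what is new or still open speak of the compounds shown alone.

- Compound 1 `COCC1=C[C@@](C)(c2cc(NC(=O)c3ccc(C#N)cn3)ccc2F)N=C(N)O1`: 61%
- Compound 2 `C[C@@]1(c2cc(NC(=O)c3ncc(OCF)nc3N)ccc2F)C=C(CF)OC(N)=N1`: 35%

Both compounds were tested in an ADME assay on microsomes from liver (Rattus norvegicus, strain Crj;CD(SD)) for metabolic stability, read by LC-MS, using NADPH, with a stated time of 30 min, tested at 0.1 uM; on this read-out lower numbers stand for a less stable compound and higher numbers for a more stable compound. Compound 2, at 35%, holds the lower of the two values, and the gap up to compound 1 lies beyond the usual scatter.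

Compound 3 `C[C@@]1(c2cc(NC(=O)c3ccc(C#N)cn3)ccc2F)C=C(CF)OC(N)=N1` is derived from compound 2 by a single change: 5-cyanopyridin-2-yl in place of 3-amino-5-(fluoromethoxy)pyrazin-2-yl on a carbonyl carbon. Going by the values given here, no measured pair isolates this change, so any expectation remains loose. The best guide is compound 1, which also carries 5-cyanopyridin-2-yl on its carbonyl carbon and gives 61%. An upward move beyond the scatter therefore seems likely. The expected size is a number 25 percentage points higher from compound 2 to compound 3 (beyond the scatter). For compound 3 the estimated value is 60%, with an expected range from 42% to 78%.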

Compound 3, percent of the compound remaining: 55%
The estimate for compound 3 lay 5 percentage points above the measured number; the measured number falls inside the stated range.
By their numbers in this assay, from the lowest: compound 2; then compounds 3 and 1 (each within the scatter of the next).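

In this assay, the group on the carbonyl carbon now has its first direct comparison: 5-cyanopyridin-2-yl in place of 3-amino-5-(fluoromethoxy)pyrazin-2-yl gives a number 20 percentage points higher from compound 2 to compound 3 (beyond the scatter) with the rest of the molecule unchanged, so the read-out responds to this position. Fluoro in place of methoxy on the saturated chain carbon bound to a double-bonded ring carbon gives a number 6 percentage points lower from compound 1 to compound 3 (within the scatter), so this change does not separate the two compounds in this read-out. Nothing measured here accounts for either result.

The carbonyl step replaces a whole group at once, leaving open which of its parts accounts for the higher number. Also open, going by these compounds, is how the read-out would respond to an amine or a carboxylic acid in place of the nitrile on the 5-cyanopyridin-2-yl group.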